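Removing the Aryl Methoxy Group in a Sulfonyl Indole Series

The source may hold more compounds than are shown below. What is called first, only, known or untested is meant among the compounds shown, and "the series" means these compounds.

Compound 2 `COc1ccc(-c2[nH]c3ccc(OC)cc3c2/C=C(\C#N)S(=O)(=O)c2ccccc2)cc1` gives 612 nM in a functional assay on SNB-75 cells (Homo sapiens) for inhibition, read by sulforhodamine B assay, with a stated time of 48 h (on this read-out lower numbers stand for stronger inhibition of growth and higher numbers for weaker inhibition of growth), the highest of the two numbers shown, although its nearest neighbour compound 1 `COc1ccc(-c2[nH]c3ccccc3c2/C=C(\C#N)S(=O)(=O)c2ccccc2)cc1` gives 379 nM and the step of a 1.6-fold higher number from compound 1 to compound 2 (0.21 log units; within the scatter) lies within the scatter. Compound 3 `COc1ccc2[nH]c(-c3ccccc3)c(/C=C(\C#N)S(=O)(=O)c3ccccc3)c2c1` differs from compound 2 by hydrogen in place of methoxy on an aromatic carbon, that is 4-methoxyphenyl to phenyl. No measured step touches this ring; the only step shown, a 1.6-fold higher number from compound 1 to compound 2 (0.21 log units; within the scatter), concerns a methoxy elsewhere in the molecule and stays within the scatter, so no shift beyond the scatter is expected. Compound 3 is therefore estimated at 500 nM, between 200 nM and 1500 nM, a step of a 1.2-fold lower number from compound 2 to compound 3 (0.09 log units; within the scatter).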

Compound 3, concentration for 50% growth inhibition: 5900 nM
For compound 3 the middle estimate is 12-fold (1.07 log units) below the measured one; measured number above the stated range.
By their numbers in this assay, from the lowest: compounds 1 and 2 (each within the scatter of the next); then compound 3.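

In this assay the change from 4-methoxyphenyl to phenyl gives a 9.6-fold higher number from compound 2 to compound 3 (0.98 log units; beyond the scatter) and so lies beyond the scatter. The earlier step of a 1.6-fold higher number from compound 1 to compound 2 (0.21 log units; within the scatter) stayed within the scatter, so the two methoxy groups do not count alike, and only removal of the one on this ring moves the number clearly. No available evidence explains this rise. On these data alone, whether an ethoxy, an amine or a fluorine on this carbon would keep the lower number stays open. So does whether removing this methoxy has the same effect in compound 1.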